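From phenethyl to diisopropylamino in a cytotoxicity assay

The source may report more compounds than this note shows. Statements on the series, on what has been measured and on what is new or still open speak of the compounds shown alone.

Going by the values given here, in an ADME assay on MDBK cells (Bos taurus) for cytotoxicity (a lower number here means that less compound is tolerated, a higher number that more compound is tolerated), compound 3 `c1ccc(CCCCn2ccc3nc(-c4ccccc4)nc-3c2)cc1` gives 95000 nM, the only true number in this small set. Compound 1 `Cc1ccccc1Cn1ccc2nc(-c3ccccc3)nc-2c1` reads > 100000 nM, which is a limit and not a number. Compound 2 `Fc1ccc(Cn2ccc3nc(-c4ccccc4)nc-3c2)cc1` reads > 100000 nM, also a limit. Among the compounds with values here, the one measured step, a step that the two limits leave unreadable from compound 1 to compound 2, therefore offers no size to carry forward, and it concerns a different change. What the measurements mainly show is the limit of > 100000 nM in this assay, at which 2 of the 3 values shown sit.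

Compound 4 `CC(C)N(CCn1ccc2nc(-c3ccccc3)nc-2c1)C(C)C` departs from compound 3 through (diisopropylamino in place of phenethyl on a saturated chain carbon, two bonds along the chain from an aromatic nitrogen). Within the data shown here, no measured step covers this exchange of diisopropylamino for phenethyl, so the expectation rests mainly on compound 3 at 95000 nM, with wide margins. The expected step, a 1.6-fold lower number from compound 3 to compound 4 (0.20 log units; within the scatter), is modest and points toward less compound being tolerated in this assay, though a result reported only as a limit remains possible. For compound 4 the estimated value is 60000 nM, with an expected range from 20000 nM to 130000 nM.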

Compound 4, half-maximal cytotoxic concentration: > 100000 nM
Compound 4: no number, only a limit; the forecaster's own chance of this, stated with the estimate: 35%; middle value at least 1.6-fold (0.22 log units) from the limit.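

In this assay, diisopropylamino in place of phenethyl, on a saturated chain carbon, two bonds along the chain from an aromatic nitrogen, gives an at least 1.0-fold higher number from compound 3 to compound 4 (0.02 log units; that floor lies within the scatter), so this position takes a group with no ring and a nitrogen without any sign of less compound being tolerated. The steps from compound 1 and from compound 2 to compound 4 join two limits and cannot be read. Compound 4 gives a limit and not a number, and it adds to what the set mainly shows: the limit of > 100000 nM in this assay, at which 3 of the 4 values shown sit.

On these data alone, how large the step to compound 4 really is stays open, since only its floor can be read. As far as these compounds go, whether a smaller amine such as dimethylamino, or a carboxylic acid, at this place would give a readable number in this assay also stays open.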